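A few compounds are considered here, and "the series" means these few. Any claim that something is new, unique, unknown or untested is made for them only; others in the source may bear on it.

Measured in a functional assay on the whole organism with Rattus norvegicus as the target (a lower number here means that less compound is needed, a higher number that more compound is needed for the effect), each value a limit of the assay:
- compound 1 `Nc1nc2ccc(I)cc2s1`: > 10 mg/kg
- compound 2 `Nc1ccc2nc(N)sc2c1`: > 10 mg/kg
- compound 3 `CCC(C)(C)c1ccc2nc(N)sc2c1`: > 10 mg/kg

Compound 3 has no number, only (the limit of > 10 mg/kg in this assay, at which 3 of the 3 values shown sit). The next analogue, compound 4 `CC(C)(C)Cc1ccc2nc(N)sc2c1`, has neopentyl in place of 1,1-dimethylpropyl on an aromatic carbon, with the same atoms joined differently: neopentyl in place of 1,1-dimethylpropyl on an aromatic carbon. The measured steps bearing on this change are a step that the two limits leave unreadable from compound 1 to compound 3 and a step that the two limits leave unreadable from compound 2 to compound 3, along with a step that the two limits leave unreadable from compound 1 to compound 2. No size or direction carries over from them, so no step beyond the scatter is expected in this assay, and the expected step is a step that the limit leaves unreadable from compound 3 to compound 4. A further limit is the likeliest report. For compound 4 the estimated value is 15 mg/kg, with an expected range of 6 mg/kg to 40 mg/kg.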

Compound 4, dose for half-maximal effect: > 10 mg/kg
Compound 4: only a limit was reported; the forecaster's own chance of this, stated with the estimate: 70%; the middle value is on the limit's open side.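

Compound 4 gives only a limit, so no step from compound 1, compound 2 or compound 3 to compound 4 can be read in this assay: the limit of > 10 mg/kg in this assay, at which 4 of the 4 values shown sit.

The compounds shown leave open whether iodo, amino, 1,1-dimethylpropyl and neopentyl differ at all, and what on the shared core would give a measurable dose.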